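The compounds below may be only part of what the source reports. "The series", "measured", "known", "first", "only" and "open" are said of these compounds alone.

Working notes on the series, read in a functional assay on HL-60 cells (Homo sapiens) for inhibition, read by MTT assay, with a stated time of 48 h, tested at 10 uM; a lower number here means less inhibition of growth, a higher number more inhibition of growth at the concentration tested. Of the compounds shown here, three sharing a core have numbers so far. Compound 1 `Cc1cc(=O)c2c(O)cc(OCc3ccccc3Br)c([C@H]3CCN(C)C[C@H]3O)c2o1` gives 3%, compound 2 `CCOC(=O)N1CCN(Cc2c(O)c([C@H]3CCN(C)C[C@H]3O)c3oc(C)cc(=O)c3c2O)CC1` gives 16%, and compound 3 `Cc1oc2c([C@H]3CCN(C)C[C@H]3O)c(O)cc(O)c2c(=O)c1C(O)c1ccc(Cl)cc1` gives 2%. Compound 3 cannot be told apart from compound 1, as their two values lie within the scatter of each other. Compound 2 stands higher than compound 3, by a gap beyond the scatter.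

Compound 4 `COc1ccc(C(O)c2c(C)oc3c([C@H]4CCN(C)C[C@H]4O)c(O)cc(O)c3c2=O)cc1Br` has not yet been measured in this assay. Its difference from compound 3 is 3-bromo-4-methoxyphenyl in place of 4-chlorophenyl on a saturated chain carbon bound to an aromatic carbon and an oxygen on a saturated carbon. In fuller terms, (4-chlorophenyl)(hydroxy)methyl becomes (3-bromo-4-methoxyphenyl)(hydroxy)methyl, on a saturated chain carbon bound to an aromatic carbon and an oxygen on a saturated carbon.

Going by the values given here, no pair of measured compounds differs in one place only, so the series offers no direct precedent for this change. Among the compounds with values here, the only guide is the spread of values, in which compound 3 at 2% and compound 2 at 16% mark the two ends. No step beyond the scatter is expected, and the estimated a number 4 percentage points higher from compound 3 to compound 4 (within the scatter) is small, with a slight upward lean. For compound 4 the expected value is 6%, with an estimated range of 0% to 18%.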

Compound 4, percent growth inhibition at one concentration: 23%
Compound 4: middle estimate off by 17 percentage points, on the low side, and the stated range ends below it.
By their numbers in this assay, from the lowest: compounds 3 and 1 (each within the scatter of the next); then compounds 2 and 4 (each within the scatter of the next).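

In this assay the aryl group at this position proves able to shift growth inhibition: with 3-bromo-4-methoxyphenyl in place of 4-chlorophenyl, the series shows a number 21 percentage points higher from compound 3 to compound 4 (beyond the scatter) and the rest of the structure stays unchanged. Going by these compounds alone, this is the first step available between compounds that differ in one place only, and it shows that a change on a saturated chain carbon bound to an aromatic carbon and an oxygen on a saturated carbon can carry the number past the scatter. Nothing measured here accounts for the step.

The change alters the ring in more than one way at once, so the compounds shown do not separate the contributions of the bromine, the methoxy group and the departing chlorine, a question that 3-bromophenyl and 4-methoxyphenyl analogues would address directly. Also open, as far as these compounds go, is how far this position tolerates other kinds of group, such as a dimethylaminomethyl or carboxylic acid substituent on the phenyl ring, and whether the hydroxy group on the same chain carbon is needed for the higher number.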